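A Longer Chain on Compound 3: Little Change Expected

The source may report more compounds than this note shows. Statements on the series, on what has been measured and on what is new or still open speak of the compounds shown alone.

In a functional assay on OVCAR-5 cells (Homo sapiens) for inhibition, with a stated time of 48 h, tested at 50 uM (a lower number here means less inhibition of growth, a higher number more inhibition of growth at the concentration tested), compound 3 (`C=C[C@@](C)(/C=C/c1ccc(OC(=O)CCCCCCCCC)cc1)CCC=C(C)C`) gives 42%. Compound 2 (`C=C[C@@](C)(/C=C/c1ccc(OC(=O)CCCCCCC)cc1)CCC=C(C)C`) gives 42%, and compound 1 (`C=C[C@@](C)(/C=C/c1ccc(OC(=O)CCC)cc1)CCC=C(C)C`) gives 41%, so these three values lie within the scatter of one another. Compound 4 (`C=C[C@@](C)(/C=C/c1ccc(OC(=O)CCCCCCCCCCCCCCC)cc1)CCC=C(C)C`) has not yet been measured, and it departs from compound 3 by a single change: hexyl in place of hydrogen on a saturated chain carbon, nine bonds along the chain from a carbonyl carbon.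

The closest guide is the same hexyl addition made three bonds along the chain from a carbonyl carbon, which gave a number 1 percentage points higher from compound 1 to compound 3 (within the scatter). Adding butyl at that place gave a number 1 percentage points higher from compound 1 to compound 2 (within the scatter), and adding ethyl seven bonds along the chain gave no change at the digits printed from compound 2 to compound 3 (within the scatter). None of these steps rises above the scatter, so no real step is expected here either. However, compound 4 has a longer chain than any compound measured so far, so the range is kept wide, particularly on the low side. The expected result is a number 2 percentage points lower from compound 3 to compound 4 (within the scatter). For compound 4 the estimated value is 40%, with an expected range from 28% to 50%.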

Compound 4, percent growth inhibition at one concentration: 64%
Compound 4: middle estimate off by 24 percentage points, on the low side; measured number outside the range, above it.
By their numbers in this assay, from the lowest: compounds 1, 2 and 3 (each within the scatter of the next); then compound 4.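

In this assay, among the compounds shown here, the hexyl addition nine bonds along the chain from a carbonyl carbon gives a number 22 percentage points higher from compound 3 to compound 4 (beyond the scatter) and is the first change on this chain to rise beyond the scatter. Compound 4 stands apart from the shorter chains too, with a number 22 percentage points higher from compound 2 to compound 4 (beyond the scatter) and a number 23 percentage points higher from compound 1 to compound 4 (beyond the scatter) as well. Compounds 1, 2 and 3 therefore sit level within the scatter, and the rise appears only with the chain of compound 4, though nothing available here explains the jump.

The compounds shown leave open where between the chains of compound 3 and compound 4 the rise begins, and whether a still longer chain would raise the number further or lower it. They also leave open whether an amine or a carboxylic acid on the chain of compound 4 would keep the rise.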